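The source may report more compounds than this note shows. Statements on the series, on what has been measured and on what is new or still open speak of the compounds shown alone.

Measured so far:
compound 1 `O=C(NCCCN1CCN(CCCNc2ccnc3cc(Cl)ccc23)CC1)c1ccc(Oc2ccccc2)cc1` gives 1400 nM
compound 2 `O=C(NCCCN1CCN(CCCNc2ccnc3cc(Cl)ccc23)CC1)c1ccc(F)c(F)c1` gives 10000 nM
compound 3 `O=C(NCCCN1CCN(CCCNc2ccnc3cc(Cl)ccc23)CC1)c1ccccc1C(=O)c1ccccc1` gives 3200 nM

These three numbers come from an ADME assay on L6 cells (Rattus norvegicus) for cytotoxicity; on this read-out higher numbers stand for weaker inhibition and lower numbers for stronger inhibition. On that read-out compound 2 stands at the top: its number is the highest of the three, and the gaps to compound 3 and to compound 1 both lie beyond the usual scatter, so compound 2 is the weakest inhibitor of the three and compound 1 the strongest. Among the compounds with values here, no pair of the measured compounds differs in only one place, so no single step is known here.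

Compound 4 `COc1cccc(C(=O)NCCCN2CCN(CCCNc3ccnc4cc(Cl)ccc34)CC2)c1` has not yet been measured in this assay. It differs from compound 2 in one place: 3-methoxyphenyl in place of 3,4-difluorophenyl on a carbonyl carbon. Within the data shown here, no measured pair shows this change, so the expectation for compound 4 can rest only on the spread of the three numbers and on the fact that compound 2 stands at the top of it. The expected step from compound 2 to compound 4 is a 1.7-fold lower number from compound 2 to compound 4 (0.22 log units; within the scatter), a modest move towards lower numbers, close to the edge of the scatter. For compound 4 the estimate is 6000 nM, with a range from 2500 nM to 15000 nM.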

Compound 4, half-maximal inhibitory concentration: 9300 nM
For compound 4 the middle estimate is 1.6-fold (0.19 log units) below the measured one; the range from low to high includes it.
By their numbers in this assay, from the lowest: compound 1; then compound 3; then compounds 4 and 2 (each within the scatter of the next).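

In this assay, putting 3-methoxyphenyl in place of 3,4-difluorophenyl on a carbonyl carbon gives a 1.1-fold lower number from compound 2 to compound 4 (0.03 log units; within the scatter), so this first single change in the series does not separate the two compounds. The change is not a trivial one on paper: both groups have 8 heavy atoms and one six-membered aromatic ring, but two fluorine atoms leave, an oxygen enters, and the count of hydrogen-bond acceptors goes from 0 to 1, yet none of this shows up as a step beyond the scatter in this read-out. Nothing available here explains why these two groups read alike.

On these data alone, one step at one place cannot show how much freedom this position allows, so it stays open whether an unsubstituted phenyl, or a phenyl carrying a carboxylic acid or an amine, on the same carbonyl carbon would also stay within the scatter of compound 2. As far as these compounds go, it is also open whether the same exchange of groups would give a similarly small step on a core with a longer chain.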